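Aryl exchange from compound 3 to compound 4

A few compounds are considered here, and "the series" means these few. Any claim that something is new, unique, unknown or untested is made for them only; others in the source may bear on it.

Values in a functional assay on MCF7 cells (Homo sapiens) for inhibition, read by sulforhodamine B assay (on this read-out higher numbers stand for weaker inhibition and lower numbers for stronger inhibition), for the shared core:
compound 1 `CCCc1ccc(NC2=CC(=O)c3nc4n(c3C2=O)[C@H]2OC[C@@H](O)[C@H]2OC4)cc1` gives 4660 nM
compound 2 `O=C1C=C(N2CCC2)C(=O)c2c1nc1n2[C@H]2OC[C@@H](O)[C@H]2OC1` gives > 16000 nM (a limit of the assay, not a number)
compound 3 `O=C1C=C(Nc2cccc(F)c2)C(=O)c2c1nc1n2[C@H]2OC[C@@H](O)[C@H]2OC1` gives 5500 nM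

Compound 3 stands level with compound 1 on the numbers, within the scatter (a 1.2-fold higher number from compound 1 to compound 3 (0.07 log units; within the scatter)). Compound 2 is held only as a limit (the limit of > 16000 nM in this assay, at which 1 of the 3 values shown sits). Compound 4 `O=C1C=C(Nc2ccc(Br)cc2)C(=O)c2c1nc1n2[C@H]2OC[C@@H](O)[C@H]2OC1` is unmeasured and carries 4-bromophenyl in place of 3-fluorophenyl on an amine nitrogen. Within the data shown here, the closest precedent is the step between compound 1 and compound 3, an exchange of one aryl group for another on that same nitrogen, and it did not leave the scatter. The other measured step (an at least 2.9-fold lower number from compound 2 to compound 3 (0.46 log units; beyond the scatter)) puts (3-fluorophenyl)amino in place of azetidin-1-yl, a change of a different kind, and compound 4 keeps an aryl group on the amine nitrogen as compound 3 does. No step beyond the scatter is therefore expected in this assay. The estimated step is small (a 1.1-fold lower number from compound 3 to compound 4 (0.06 log units; within the scatter)). For compound 4 the estimated value is 4800 nM (2000 nM to 11000 nM).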

Compound 4, half-maximal inhibitory concentration: 2580 nM
Compound 4: the middle estimate sits 1.9-fold (0.27 log units) above what was measured; low and high end bracket the measured number.
By their numbers in this assay, from the lowest: compounds 4, 1 and 3 (each within the scatter of the next, the first and the last beyond it). At a limit, above all of these: compound 2.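

In this assay, the aryl group on the amine nitrogen now proves able to move the number beyond the scatter, with 4-bromophenyl in place of 3-fluorophenyl (a 2.1-fold lower number from compound 3 to compound 4 (0.33 log units; beyond the scatter)), which the earlier aryl exchange did not do. The change is not a clear separation from every aryl group, as bromo in place of propyl on an aromatic carbon stays within the scatter (a 1.8-fold lower number from compound 1 to compound 4 (0.26 log units; within the scatter)). The (4-bromophenyl)amino group in place of azetidin-1-yl gives a step that is only a bound (an at least 6.2-fold lower number from compound 2 to compound 4 (0.79 log units; beyond the scatter)), since compound 2 is held as a limit: (the limit of > 16000 nM in this assay, at which 1 of the 4 values shown sits).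

The halogen and its place on the ring change together in the step to compound 4, and the compounds shown do not separate the two. On these data alone, a 4-fluorophenyl or 3-bromophenyl group on the same nitrogen remains open as the comparison that would.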